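From 4-chlorophenyl to 3,4-difluorophenyl: an oral question

The source may hold more compounds than are shown below. What is called first, only, known or untested is meant among the compounds shown, and "the series" means these compounds.

Two compounds have so far gone through an ADME assay on the whole organism (Rattus norvegicus, strain Sprague-Dawley) for pharmacokinetics, using cassette dosing, at a dose of 1 mg/kg by the oral route; a higher number here means that a larger share of the oral dose reaches the circulation, a lower number that a smaller share of the oral dose reaches the circulation. In it, compound 1 (`O[C@]1(Cc2cc(-c3cn[nH]c3)on2)CC[C@@H](Cc2ccc(C(F)(F)F)cc2)CC1`) gives 67.5%, and compound 2 (`O=C(Nc1ccc2[nH]c(=O)oc2c1)C(=O)N1CCN(c2ccc(Cl)cc2)CC1`) gives 17.8%. Compound 2 therefore holds the lower of the two numbers, and its gap to compound 1 lies beyond the scatter. The two structures differ in more than one place, so this gap cannot be tied to any single group.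

Compound 3 (`O=C(Nc1ccc2[nH]c(=O)oc2c1)C(=O)N1CCN(c2ccc(F)c(F)c2)CC1`) keeps the core of compound 2 and has 3,4-difluorophenyl in place of 4-chlorophenyl on an amine nitrogen in a ring. Within the data shown here, no two measured compounds differ in one place only, so the data give no direct measure of what such a swap does in this assay. Among the measured compounds shown here, the only close reference is compound 2 at 17.8%, and no step beyond the scatter is expected from it. The expected change is a number 2.2 percentage points higher from compound 2 to compound 3 (within the scatter), a small rise that stays within the scatter. Compound 3 is estimated at 20%, with an expected range from 8% to 38%.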

Compound 3, oral bioavailability: 13%
For compound 3 the middle estimate is 7 percentage points above the measured one, and the stated range covers the measured number.
By their numbers in this assay, from the lowest: compounds 3 and 2 (each within the scatter of the next); then compound 1.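

In this assay, among these compounds, putting 3,4-difluorophenyl in place of 4-chlorophenyl on an amine nitrogen in a ring gives a number 4.8 percentage points lower from compound 2 to compound 3 (within the scatter), and this is the first step that can be read at a single place. At this position, three ring bonds from the ring nitrogen, the read-out therefore does not separate the two halogen-bearing phenyl groups, even though one carries chlorine and the other two fluorines, and the shared core with these two groups gives no sign of a difference in how much of the oral dose reaches the circulation. Nothing at hand bears on what sets that share for either compound.

What the compounds shown leave open is whether a group of another kind on the same nitrogen, such as a pyridyl ring, a plain phenyl or a methoxyphenyl, would give a step beyond the scatter. They also leave open how far the number depends on the rest of the shared core, for instance if a methyl group took the place of the amide hydrogen.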